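Swapping a Nitrile for an Isopentyloxy Chain on the Core

A few compounds are considered here, and "the series" means these few. Any claim that something is new, unique, unknown or untested is made for them only; others in the source may bear on it.

Compound 1, `COc1cccc2c(=O)cc(/C=C/[S+](C)[O-])oc12`: 9000 nM
Compound 3, `COc1ccc2c(=O)cc(/C=C/[S+](C)[O-])oc2c1`: 7800 nM
Compound 2, `C[S+]([O-])/C=C/c1cc(=O)c2cc(C#N)ccc2o1`: > 10000 nM

These three compounds share one core and were tested in a functional assay on DLD-1 cells (Homo sapiens) for cytotoxicity, with a stated time of 48 h; a lower number here means a stronger inhibitor, a higher number a weaker inhibitor. Compound 1 gives 9000 nM and compound 3 gives 7800 nM, two values that lie within the usual scatter of each other. For compound 2 the assay reports only a limit, > 10000 nM. Compound 2 therefore stands at the limit of > 10000 nM in this assay, at which 1 of the 3 values shown sits. Compound 4, `CC(C)CCOc1ccc2oc(/C=C/[S+](C)[O-])cc(=O)c2c1`, differs from compound 2 by isopentyloxy in place of cyano on an aromatic carbon. Going by the values given here, no measured pair shows this change, so no measured step guides the direction, and all three measured compounds are weak. The expected step, an at least 1.1-fold lower number from compound 2 to compound 4 (0.04 log units; that floor lies within the scatter), is small and within the scatter. Compound 4 is estimated at 9000 nM, with a range from 3000 nM to 30000 nM.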

Compound 4, half-maximal inhibitory concentration: 4100 nM
The estimate for compound 4 lay 2.2-fold (0.34 log units) above the measured number; low and high end bracket the measured number.
By their numbers in this assay, from the lowest: compounds 4, 3 and 1 (each within the scatter of the next, the first and the last beyond it). At a limit, above all of these: compound 2.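

In this assay, going by these compounds alone, isopentyloxy in place of cyano on this aromatic carbon gives an at least 2.4-fold lower number from compound 2 to compound 4 (0.38 log units; beyond the scatter), the first measured change at this position. The true step may be larger, since compound 2 carries only a limit: the limit of > 10000 nM in this assay, at which 1 of the 4 values shown sits. The result shows that this aromatic carbon can carry the larger isopentyloxy chain without the number rising. The compounds shown cannot tell whether the gain comes from adding the chain or from losing the nitrile. On these data alone, how a longer chain or an amine on this carbon would compare also stays open.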